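Removing an acetyl from a diterpenoid: expected cytotoxicity shift

The source may hold more compounds than are shown below. What is called first, only, known or untested is meant among the compounds shown, and "the series" means these compounds.

Compound 1 `C=C1CC[C@@H]2[C@](C)(CO[Si](c3ccccc3)(c3ccccc3)C(C)(C)C)[C@H](OC(C)=O)CC[C@@]2(C)[C@@H]1C/C=C1/C(=O)OC[C@H]1OC(C)=O`: 32.8 uM
Compound 2 `C=C1CC[C@@H]2[C@](C)(CO[Si](C)(C)C(C)(C)C)[C@H](OC(C)=O)CC[C@@]2(C)[C@@H]1C/C=C1/C(=O)OC[C@H]1O`: 8.17 uM

In a functional assay on ASK cells (Rattus norvegicus) for cytotoxicity, read by sulforhodamine B assay (a lower number here means that less compound is needed, a higher number that more compound is needed for the effect), compound 1 gives 32.8 uM, the highest of the two numbers measured; compound 2 gives a lower number, and that gap lies beyond the scatter. Among the compounds with values here, no pair differing in one place has been measured. Compound 3 `C=C1CC[C@@H]2[C@](C)(CO[Si](c3ccccc3)(c3ccccc3)C(C)(C)C)[C@H](O)CC[C@@]2(C)[C@@H]1C/C=C1/C(=O)OC[C@H]1OC(C)=O` differs from compound 1 by hydrogen in place of acetyl on an oxygen on a saturated carbon. Without a single-change precedent, a modest step downward is expected, possibly not beyond the scatter. For compound 3 the estimated value is 20 uM, between 8 uM and 50 uM, which means an expected step of a 1.6-fold lower number from compound 1 to compound 3 (0.21 log units; within the scatter).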

Compound 3, concentration for half-maximal effect: 12 uM
Compound 3: middle estimate off by 1.7-fold (0.22 log units), on the high side; the measured number falls inside the stated range.
By their numbers in this assay, from the lowest: compounds 2 and 3 (each within the scatter of the next); then compound 1.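

In this assay hydrogen in place of acetyl on this oxygen gives a 2.7-fold lower number from compound 1 to compound 3 (0.44 log units; beyond the scatter) as the first single change available here. It shows that this position alone can move the number, by a modest step that still lies beyond the scatter, and that a free hydroxy goes with less compound being needed. No evidence on the cause of this step is available.

Going by these compounds, whether the acetoxy group that compound 3 retains would respond in the same way remains open. So does how a methyl ether or an amine would behave at this position.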